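This account rests on a few compounds, and the source may have more. Where it says the series, first, only, none or still open, it means among the compounds named here.

Compound 1 `CC(C)(C)c1nc2c(OCc3ccccc3)cccn2c1N` gives 0% in a functional assay on the whole organism with Canis familiaris (Canis lupus familiaris) as the target, at a dose of 8 mg/kg by the oral route; on this read-out higher numbers stand for a stronger effect at the one dose given and lower numbers for a weaker effect. Compound 2 `Cc1nc2c(OCc3ccc(F)cc3)cccn2c1N` gives 93%. Compound 3 `Cc1nc2c(OCc3ccccn3)cccn2c1N` gives 15%.

Among these three numbers compound 3 stands second highest: its nearest neighbour is compound 1, which lies lower by a margin beyond the scatter, and compound 2 lies far higher, also beyond the scatter. Compound 4 `Cc1nc2c(OCc3ccsc3)cccn2c1N` has not yet been tested. It differs from compound 3 by thiophen-3-yl in place of pyridin-2-yl on a saturated chain carbon bound to an oxygen on an aromatic ring. Among the compounds with values here, no step between measured compounds involves this exchange, so its size is not known from the data. In this assay a moderate rise is expected, with a wide range that also allows for no change beyond the scatter. The expected step from compound 3 to compound 4 is a number 30 percentage points higher from compound 3 to compound 4 (beyond the scatter). For compound 4 the estimate is 45%, between 10% and 85%.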

Compound 4, a percentage reported as inhibition, in the whole organism at one dose (the size of the read-out at that dose, not a potency): 88%
The estimate for compound 4 lay 43 percentage points below the measured number; the measured number lies above the stated range.
By their numbers in this assay, from the lowest: compound 1; then compound 3; then compounds 4 and 2 (each within the scatter of the next).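

In this assay, the ring at this place, on a saturated chain carbon bound to an oxygen on an aromatic ring, proves decisive at the one dose given: thiophen-3-yl in place of pyridin-2-yl gives a large rise, a number 73 percentage points higher from compound 3 to compound 4 (beyond the scatter). Compound 4 gives 88% and compound 2 gives 93%, within the scatter of each other, so the low number of compound 3 does not extend to every ring here. No evidence at hand explains the step.

As far as these compounds go, it remains open whether pyridin-3-yl or thiophen-2-yl at this place would read like compound 3 or compound 4.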